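Extending the thiol-bearing chain of compound 1 toward compound 4

The source may hold more compounds than are shown below. What is called first, only, known or untested is meant among the compounds shown, and "the series" means these compounds.

Compound 1 `CC(C)(C)OC(=O)N[C@@H](CCCCS)C(=O)NC1CCCC1` is a Boc-protected amino acid amide bearing a terminal thiol. In an assay on isolated protein for inhibition of protein deacetylase HDAC6 (Homo sapiens), read by fluorescence, tested at 1 uM (a lower number here means less inhibition, a higher number more inhibition at the concentration tested (going by the name of the read-out)), compound 1 gives 50%, the second highest of the three numbers shown. Compound 2 `O=C(O)CCCCC[C@H](NC(=O)OCc1ccccc1)C(=O)NC1CCCC1` gives 40%, and compound 3 `COC(=O)CCCCC[C@H](NC(=O)OC(C)(C)C)C(=O)NC1CCCC1` gives 60%; the step of a number 10 percentage points higher from compound 1 to compound 3 (within the scatter) lies within the scatter, as does the gap between compound 1 and compound 2.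

Compound 4 `CC(C)(C)OC(=O)N[C@@H](CCCCCCS)C(=O)NC1CCCC1` differs from compound 1 as follows: 2-sulfanylethyl in place of sulfanyl on a saturated chain carbon, five bonds along the chain from an amide-type nitrogen and a carbonyl carbon. Among the compounds with values here, no measured pair changes the chain in this way; the only single-point step available, from compound 1 to compound 3, exchanges the terminal group rather than the chain and is within the scatter. With nothing beyond the scatter among the three measured compounds, compound 4 is estimated to sit near compound 1, so that the expected step of a number 5 percentage points higher from compound 1 to compound 4 (within the scatter) is not beyond the scatter. Compound 4 is therefore expected to give about 55% in this assay, within a range of 30% to 80%.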

Compound 4, a percentage reported as inhibition, at one concentration (the size of the read-out at that concentration, not a potency): 60%
For compound 4 the middle estimate is 5 percentage points below the measured one; low and high end bracket the measured number.
By their numbers in this assay, from the lowest: compounds 2, 1, 3 and 4 (each within the scatter of the next, the first and the last beyond it).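

In this assay, 2-sulfanylethyl in place of sulfanyl on a saturated chain carbon, five bonds along the chain from an amide-type nitrogen and a carbonyl carbon, gives a number 10 percentage points higher from compound 1 to compound 4 (within the scatter) and so shows that this position accepts the two added carbons, with the thiol kept at the chain end, without a step beyond the scatter. At the chain end, sulfanylmethyl in place of methoxycarbonyl gives no change at the digits printed from compound 3 to compound 4 (within the scatter) and leaves the thiol and methyl ester compounds not told apart by this read-out. No supporting measurement bears on either step.

From the compounds shown here alone, whether a longer chain such as 5-sulfanylpentyl would give a step beyond the scatter stays open. So does the effect of an amine or a hydroxamic acid at the chain end.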